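The source may hold more compounds than are shown below. What is called first, only, known or untested is meant among the compounds shown, and "the series" means these compounds.

Of the compounds shown here, two that share a core have been tested in a functional assay on BXPC-3 cells (Homo sapiens) for antiproliferative activity, read by sulforhodamine B assay, with a stated time of 72 h; on this read-out higher numbers stand for weaker inhibition and lower numbers for stronger inhibition. Compound 1 `CCCSc1ccc2c3c(cccc13)C1=NC(=O)C(C(=O)OCC)=C12`, which carries a propylsulfanyl group and an ethyl ester, gives 5800 nM. Compound 2 `O=C(COC(=O)C1=C2C(=NC1=O)c1cccc3cccc2c13)OCC(F)(F)C(F)(F)F`, which lacks that group and carries a different, fluorinated ester, gives 23300 nM. That is the higher of the two numbers, and the gap between them lies beyond the scatter. The two compounds differ in more than one place, so no single change can be read from this gap.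

Compound 3 `CCCSc1ccc2c3c(cccc13)C1=NC(=O)C(C(=O)OCC(=O)OCC(F)(F)C(F)(F)F)=C12` keeps the ester of compound 2 and changes one thing: propylsulfanyl in place of hydrogen on an aromatic carbon. For the measured compounds named here, no measured pair isolates this change. Going by the values given here, the only guide is compound 1, which bears the same group and gives 5800 nM, so a moderate move toward stronger inhibition in this assay is expected, probably beyond the scatter. The expected size of the change is a 3.3-fold lower number from compound 2 to compound 3 (0.52 log units; beyond the scatter). The estimated value for compound 3 is 7000 nM, with an expected range from 2500 nM to 18000 nM.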

Compound 3, half-maximal inhibitory concentration: 54100 nM
For compound 3 the middle estimate is 7.7-fold (0.89 log units) below the measured one, and the stated range ends below it.
By their numbers in this assay, from the lowest: compound 1; then compound 2; then compound 3.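

In this assay the step with propylsulfanyl in place of hydrogen on an aromatic carbon is a 2.3-fold higher number from compound 2 to compound 3 (0.37 log units; beyond the scatter) and goes toward weaker inhibition, so with the fluorinated ester in place this group does not bring the stronger inhibition that compound 1 alone might have implied. For the compounds shown here, with propylsulfanyl held constant, the step with (2,2,3,3,3-pentafluoropropoxy)carbonyl in place of methyl on a saturated chain carbon bound to an oxygen next to a carbonyl group is a 9.3-fold higher number from compound 1 to compound 3 (0.97 log units; beyond the scatter) and also goes toward weaker inhibition, giving the first reading of the ester change on its own. The compounds offer no measurement that would explain either step.

It remains open how propylsulfanyl acts alongside the ethyl ester, as the compounds shown include no partner with hydrogen in that place and the ethyl ester, so the step might differ in size or direction there. Also open, on these data alone, is whether a methylsulfanyl group or an amine on the same aromatic carbon, or a carboxylic acid in place of the ester, would move the number toward stronger or weaker inhibition.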